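Aryl amide exchange on the thiourea compound

This account rests on a few compounds, and the source may have more. Where it says the series, first, only, none or still open, it means among the compounds named here.

Compound 1 `NC(=O)c1c(NC(=O)c2ccccc2F)sc2c1CCN(Cc1cccc(Cl)c1)C2` and compound 2 `NC(=O)c1c(NC(=O)c2ccccc2I)sc2c1CCN(C(=S)Nc1ccccc1Cl)C2` share one core and differ from each other in more than one place, so no single step can be read between them. In a functional assay on MKN-74 cells (Homo sapiens) for antiproliferative activity, with a stated time of 24 h (on this read-out lower numbers stand for stronger inhibition and higher numbers for weaker inhibition), compound 1 gives 23300 nM. In this assay compound 2 gives 17500 nM, which sits within the scatter of the number for compound 1; the two compounds are not separated on this read-out. Compound 3 `Cc1ccc(C(=O)Nc2sc3c(c2C(N)=O)CCN(C(=S)Nc2ccccc2Cl)C3)cc1` differs from compound 2 in one place: 4-methylphenyl in place of 2-iodophenyl on a carbonyl carbon. Among the measured compounds shown here, no measured pair shows this change, so nothing here sets its size. For compound 3 the step of a 1.1-fold higher number from compound 2 to compound 3 (0.06 log units; within the scatter) is expected to be small, with no direction beyond the scatter. Compound 3 is therefore estimated at 20000 nM, with a range from 6000 nM to 60000 nM.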

Compound 3, half-maximal inhibitory concentration: 11300 nM
For compound 3 the middle estimate is 1.8-fold (0.25 log units) above the measured one, within the range that was stated.
By their numbers in this assay, from the lowest: compounds 3, 2 and 1 (each within the scatter of the next, the first and the last beyond it).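

Among the compounds shown here, the first one-place pair is at the carbonyl carbon of the aryl amide, where 4-methylphenyl in place of 2-iodophenyl gives a 1.5-fold lower number from compound 2 to compound 3 (0.19 log units; within the scatter) in this assay. Both groups have the same heavy-atom count and a six-membered aromatic ring of carbon only, but one carries iodine and the other does not, and this read-out does not separate the two compounds. So this single exchange of aryl groups at this position, with the thiourea side held fixed, leaves the antiproliferative number within the scatter, and no outside evidence bears on this result.

From the compounds shown here alone, it remains open whether a group of another kind on this carbonyl carbon, such as a pyridine ring, an aryl group bearing a carboxylic acid or an amine, or a longer alkyl chain, would move the number beyond the scatter. Going by these compounds, it is also open whether the same exchange would read the same with the other side of the molecule as in compound 1.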